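The source may hold more compounds than are shown below. What is called first, only, known or untested is meant among the compounds shown, and "the series" means these compounds.

Compound 1, `CC(=O)O[C@@H]1C=CC(=O)O[C@@H]1[C@@H](COC(=O)c1ccc(Cl)cc1)OC(C)=O`, gives 24400 nM in a functional assay on Jurkat cells (Homo sapiens) for antiproliferative activity, read by MTT assay, with a stated time of 6 days; on this read-out higher numbers stand for weaker inhibition and lower numbers for stronger inhibition.
Compound 2, `CC(=O)O[C@@H]1C=CC(=O)O[C@@H]1[C@@H](COC(=O)c1ccc([N+](=O)[O-])cc1)OC(C)=O`, gives 7450 nM.
Compound 3, `COc1ccc(/C=C/C(=O)OC[C@@H](OCc2ccccc2)[C@H]2OC(=O)C=C[C@H]2OCc2ccccc2)cc1`, gives 10300 nM.

Compound 3 holds the second highest of the three numbers: its value sits within the scatter of that of compound 2, while that of compound 1 lies beyond the scatter, higher. Compound 4, `O=C1C=C[C@@H](OCc2ccccc2)[C@@H]([C@@H](COC(=O)/C=C/c2ccc([N+](=O)[O-])cc2)OCc2ccccc2)O1`, differs from compound 3 by nitro in place of methoxy on an aromatic carbon. Among the compounds with values here, one measured step bears on this: a 3.3-fold lower number from compound 1 to compound 2 (0.52 log units; beyond the scatter), where a nitro group likewise entered on the aromatic ring, though there it replaced chloro rather than methoxy. A step of similar direction, a lower number, is therefore expected, but its size is uncertain. Compound 4 is expected to give about 4000 nM, between 1500 nM and 11000 nM. This amounts to an expected step of a 2.6-fold lower number from compound 3 to compound 4 (0.41 log units; beyond the scatter).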

Compound 4, half-maximal inhibitory concentration: 5710 nM
Compound 4: middle estimate off by 1.4-fold (0.15 log units), on the low side; the measured number falls inside the stated range.
By their numbers in this assay, from the lowest: compounds 4, 2 and 3 (each within the scatter of the next); then compound 1.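

With the 2-(4-methoxyphenyl)ethenyl group as the starting point, nitro in place of methoxy gives a 1.8-fold lower number from compound 3 to compound 4 (0.26 log units; within the scatter), so the two groups cannot be told apart at this aromatic carbon. Nitro in place of chloro gave a 3.3-fold lower number from compound 1 to compound 2 (0.52 log units; beyond the scatter), so a nitro group entering the ring does not produce a step beyond the scatter with every group it replaces. No measurement here explains this difference between the two changes. Still open, on these data alone, is how an amine or a carboxylic acid at this place would read, and whether a chloro group here would fall with compound 3 and compound 4 or apart from them.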